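Replacing pyrimidin-5-yl with pyridin-3-yl in compound 2

The compounds below may be only part of what the source reports. "The series", "measured", "known", "first", "only" and "open" are said of these compounds alone.

In a functional assay on SK-BR-3 cells (Homo sapiens) for inhibition, read by MTT assay (a higher number here means a weaker inhibitor of growth, a lower number a stronger inhibitor of growth), compound 1 `CC1=C(/C=C/C(C)=C/C=C/C(C)=C\C(=O)NCc2ccc(O)cc2)C(C)(C)CC=C1c1cncnc1` gives 11500 nM, compound 2 `CC1=C(/C=C/C(C)=C/C=C/C(C)=C\C(=O)Nc2ccccc2)C(C)(C)CC=C1c1cncnc1` gives 31000 nM and compound 3 `CC1=C(/C=C/C(C)=C/C=C/C(C)=C\C(=O)NCc2ccc(O)cc2)C(C)(C)CCC1n1ccnc1` gives 2450 nM. Compound 2 therefore has the highest number of the three and is the weakest inhibitor of growth among them.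

Compound 4 `CC1=C(/C=C/C(C)=C/C=C/C(C)=C\C(=O)Nc2ccccc2)C(C)(C)CC=C1c1cccnc1` keeps the phenyl on the amide-type nitrogen of compound 2 but carries pyridin-3-yl in place of pyrimidin-5-yl on a double-bonded ring carbon. Among the measured compounds shown here, only one measured step bears on this comparison, and only indirectly. That modest step, a 2.7-fold higher number from compound 1 to compound 2 (0.43 log units; beyond the scatter), is phenyl in place of 4-hydroxybenzyl on an amide-type nitrogen, not a change at this ring carbon. Compound 3 differs from compound 1 in the core and offers no single-place comparison. With no measurement of this exchange itself, no step beyond the scatter is expected in this assay. The expected change is a 1.3-fold lower number from compound 2 to compound 4 (0.11 log units; within the scatter). Compound 4 is estimated at 24000 nM, with an expected range of 9000 nM to 60000 nM.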

Compound 4, concentration for 50% growth inhibition: 47400 nM
For compound 4 the middle estimate is 2.0-fold (0.30 log units) below the measured one; low and high end bracket the measured number.
By their numbers in this assay, from the lowest: compound 3; then compound 1; then compounds 2 and 4 (each within the scatter of the next).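

Among the compounds shown here, this is the first exchange at the double-bonded ring carbon that can be read directly, and in this assay it gives a 1.5-fold higher number from compound 2 to compound 4 (0.18 log units; within the scatter). With the phenyl on the amide-type nitrogen held fixed, pyridin-3-yl and pyrimidin-5-yl therefore cannot be told apart at this position, even though the entering ring has one hetero atom and one hydrogen-bond acceptor fewer than the ring it replaces. No measured evidence on either ring at this position is available to account for this reading.

The compounds shown leave open whether the two rings would also match with 4-hydroxybenzyl on the amide-type nitrogen. They also leave open how this ring carbon would respond to a plain phenyl ring, an amine or a carboxylic acid in place of these rings.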